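Cyano for piperazin-1-yl on the chain

The compounds below may be only part of what the source reports. "The series", "measured", "known", "first", "only" and "open" are said of these compounds alone.

In an ADME assay on MT4 cells (Homo sapiens) for cytotoxicity, read by MTT assay, with a stated time of 5 days (a higher number here means that more compound is tolerated, a lower number that less compound is tolerated), compound 1 `COCCNc1cc(Oc2c(C)cc(/C=C/C#N)cc2C)nc(Nc2ccc(C#N)cc2)n1` gives 3190 nM while compound 2 `C=CCNc1cc(Oc2c(C)cc(/C=C/C#N)cc2C)nc(Nc2ccc(C#N)cc2)n1` gives 3050 nM and compound 3 `Cc1cc(/C=C/C#N)cc(C)c1Oc1cc(NCCN2CCNCC2)nc(Nc2ccc(C#N)cc2)n1` gives 3650 nM on the same read-out. Compound 3 therefore stands level with the other two. The steps are a 1.1-fold higher number from compound 1 to compound 3 (0.06 log units; within the scatter) and a 1.2-fold higher number from compound 2 to compound 3 (0.08 log units; within the scatter) along with a 1.0-fold lower number from compound 1 to compound 2 (0.02 log units; within the scatter) and all stay within the scatter.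

Compound 4 `Cc1cc(/C=C/C#N)cc(C)c1Oc1cc(NCCC#N)nc(Nc2ccc(C#N)cc2)n1` carries cyano in place of piperazin-1-yl on a saturated chain carbon, two bonds along the chain from a nitrogen on an aromatic ring. The three measured steps bear on this change, since each alters the same chain. Among the measured compounds shown here, none of the measured compounds has cyano at this place, so the evidence is indirect. No step beyond the scatter is expected in this assay for this change. Compound 4 is estimated at 3300 nM with an expected range from 1700 nM to 6500 nM on this read-out. The estimate means a 1.1-fold lower number from compound 3 to compound 4 (0.04 log units; within the scatter) as the expected step.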

Compound 4, half-maximal cytotoxic concentration: 1000 nM
Estimate against measurement, compound 4: 3.3-fold (0.52 log units) above, and the stated range ends above it.
By their numbers in this assay, from the lowest: compound 4; then compounds 2, 1 and 3 (each within the scatter of the next).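

In this assay the end of this chain is not indifferent after all: cyano in place of piperazin-1-yl gives a 3.7-fold lower number from compound 3 to compound 4 (0.56 log units; beyond the scatter), although compound 1, compound 2 and compound 3 stand level with one another. The other two comparisons agree, with cyanomethyl in place of vinyl giving a 3.1-fold lower number from compound 2 to compound 4 (0.48 log units; beyond the scatter) and cyano in place of methoxy giving a 3.2-fold lower number from compound 1 to compound 4 (0.50 log units; beyond the scatter), so among the four compounds shown only the 2-cyanoethyl chain of compound 4 stands apart. Nothing available explains why this change lowers the number.

On these data alone, whether this step belongs to cyano alone remains open, as a carboxylic acid or a primary amide at this place could show. A longer chain ending in cyano would show whether the step persists when the cyano group sits further out.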